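The source may hold more compounds than are shown below. What is called first, only, known or untested is meant among the compounds shown, and "the series" means these compounds.

In an assay on CHO cells for antagonist activity at transient receptor potential cation channel subfamily V member 1 (Homo sapiens), read by FLIPR (a lower number here means a stronger inhibitor, a higher number a weaker inhibitor), compound 1 `CC1CCN(c2nc(C3CC3)ccc2CNC(=O)C(C)c2ccc(NS(C)(=O)=O)c(F)c2)CC1` gives 0.9 nM and compound 2 `CC(C(=O)NCc1ccc(C(F)(F)Cl)nc1N1CCCCC1)c1ccc(NS(C)(=O)=O)c(F)c1` gives 1.3 nM.

Compound 2 has the higher of the two numbers, but its gap to compound 1 lies within the scatter, so the two cannot be told apart. Compound 3 `CC(C(=O)NCc1ccc(C(F)(F)Cl)nc1N1CCN(c2ccccc2)CC1)c1ccc(NS(C)(=O)=O)c(F)c1` differs from compound 2 in one place: 4-phenylpiperazin-1-yl in place of piperidin-1-yl on an aromatic carbon. For the measured compounds named here, no measured pair shows the effect of such a change here, so only the size of the added group guides the expectation. A modest loss of potency, beyond the scatter, is expected, with the estimated step of a 3.1-fold higher number from compound 2 to compound 3 (0.49 log units; beyond the scatter). For compound 3 the expected value in this assay is 4 nM, within a range of 1 nM to 25 nM.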

Compound 3, inhibition constant: 0.8 nM
Estimate against measurement, compound 3: 5.0-fold (0.70 log units) above, outside the stated range (below it).
By their numbers in this assay, from the lowest: compounds 3, 1 and 2 (each within the scatter of the next).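

In this assay, placing 4-phenylpiperazin-1-yl instead of piperidin-1-yl on this aromatic carbon gives a 1.6-fold lower number from compound 2 to compound 3 (0.21 log units; within the scatter) and so leaves the two compounds indistinguishable. This position next to the ring nitrogen therefore accepts a much larger group, with an added aromatic ring, without a measurable loss of potency. No available measurement explains this tolerance.

Still open, as far as these compounds go, is whether a fluoro or methoxy group on the outer phenyl ring would keep this potency. The same question applies to a 4-methylpiperazin-1-yl group, which has a methyl in place of that ring.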